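The source may report more compounds than this note shows. Statements on the series, on what has been measured and on what is new or still open speak of the compounds shown alone.

Of the compounds shown here, three sharing one core have been measured in an assay on the whole organism (plasma, strain Sprague-Dawley) for inhibition of Dipeptidyl peptidase 4 (Rattus norvegicus), with a stated time of 6 h, at a dose of 1 mg/kg by the oral route; on this read-out lower numbers stand for less inhibition and higher numbers for more inhibition at the one dose given (going by the name of the read-out). Compound 1 `CCC[C@@H]1CN[C@H](C(=O)N2CCC[C@H]2C#N)C1` carries a propyl group on a saturated ring carbon of the core, and in this assay compound 1 gives 50%. Compound 2 `CN(C)C(=O)C[C@@H]1CN[C@H](C(=O)N2CCC[C@H]2C#N)C1` carries a dimethylcarbamoyl group on a saturated chain carbon bound to a saturated ring carbon, and compound 2 gives 66%. Compound 3 `CCN(C)C(=O)[C@@H]1CN[C@H](C(=O)N2CCC[C@H]2C#N)C1` carries an ethyl(methyl)carbamoyl group on the saturated ring carbon itself, and compound 3 gives 71%. Compound 3 thus stands highest of the three numbers; its lead over compound 1 lies beyond the scatter, while its gap to compound 2 lies within it. The two steps from the alkyl compound to the carbamoyl compounds are a number 16 percentage points higher from compound 1 to compound 2 (beyond the scatter) and a number 21 percentage points higher from compound 1 to compound 3 (beyond the scatter); the step between the two carbamoyl compounds is a number 5 percentage points higher from compound 2 to compound 3 (within the scatter).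

Compound 4 `N#C[C@@H]1CCCN1C(=O)[C@@H]1CCCN1` strips the ring substituent away: hydrogen in place of ethyl(methyl)carbamoyl on a saturated ring carbon. Among the compounds with values here, no measured step shows what hydrogen does at this ring carbon; the measured steps show only that a carbamoyl group, on the ring carbon or on a chain carbon bound to it, gave a higher number than propyl. Removing the group that came with the highest number is therefore expected to lower the read-out, the expected step being a number 31 percentage points lower from compound 3 to compound 4 (beyond the scatter). Compound 4 is expected to give about 40% in this assay, within a range from 20% to 62%.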

Compound 4, a percentage reported as inhibition, in the whole organism at one dose (the size of the read-out at that dose, not a potency): 20%
The estimate for compound 4 lay 20 percentage points above the measured number; the measured number falls inside the stated range.
By their numbers in this assay, from the lowest: compound 4; then compound 1; then compounds 2 and 3 (each within the scatter of the next).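

In this assay, a bare ring carbon gives a number 51 percentage points lower from compound 3 to compound 4 (beyond the scatter), a number 46 percentage points lower from compound 2 to compound 4 (beyond the scatter) and a number 30 percentage points lower from compound 1 to compound 4 (beyond the scatter), so each of the three groups shown at this position goes with a higher number than hydrogen. The earlier compounds shown here could only set carbamoyl groups against propyl, whereas compound 4 supplies the missing baseline: even the plain propyl chain of compound 1 stands clear of it, and the two carbamoyl compounds stand further from it still. Nothing measured here bears on why removing these groups lowers the number, so the change can be described but not explained.

The compounds shown leave open how small a group on this ring carbon can be and still lift the number above that of compound 4, as a methyl or a hydroxyl might test, and whether an amine or a carboxylic acid in the same place would match the carbamoyl compounds. They also leave open whether a longer chain would go beyond propyl, and whether any of these groups would give the same number with the opposite orientation on the ring carbon.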